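From Pyridine to Furan on the Shared Core

The source may report more compounds than this note shows. Statements on the series, on what has been measured and on what is new or still open speak of the compounds shown alone.

Among the three measured compounds, compound 3 `CSc1ccc(C2=C(c3ccncc3)C(=O)N3CCCC3C2)cc1` stands lowest in a functional assay on HCT-116 cells (Homo sapiens) for cytotoxicity (a lower number here means a stronger inhibitor, a higher number a weaker inhibitor), at 6000 nM; compound 2 `COc1ccc(C2=C(c3ccncc3)C(=O)N3CCCC3C2)cc1` gives 19000 nM and compound 1 `COc1ccc(C2=C(c3ccccn3)C(=O)N3CCCC3C2)cc1` gives 104000 nM. Compound 4 `CSc1ccc(C2=C(c3ccoc3)C(=O)N3CCCC3C2)cc1` differs from compound 3 by furan-3-yl in place of pyridin-4-yl on a double-bonded ring carbon. For the measured compounds named here, the only measured step at that place is a 5.5-fold lower number from compound 1 to compound 2 (0.74 log units; beyond the scatter), a swap between two pyridyl groups, while the step of a 3.2-fold lower number from compound 2 to compound 3 (0.50 log units; beyond the scatter) lies elsewhere on the shared core. Going by the values given here, no measured compound carries a furan, so the direction of this change is untested. Because the ring at this place already shifted the number by a 5.5-fold lower number from compound 1 to compound 2 (0.74 log units; beyond the scatter), a modest step is expected for compound 4, most likely upward, a 2.0-fold higher number from compound 3 to compound 4 (0.30 log units; within the scatter). Compound 4 is therefore estimated at 12000 nM, within 3000 nM to 50000 nM.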

Compound 4, half-maximal inhibitory concentration: 1100 nM
Beside the measured number, compound 4's estimate is 11-fold (1.04 log units) above it; measured number outside the range, below it.
By their numbers in this assay, from the lowest: compound 4; then compound 3; then compound 2; then compound 1.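

In this assay, furan-3-yl in place of pyridin-4-yl gives a 5.5-fold lower number from compound 3 to compound 4 (0.74 log units; beyond the scatter), so this position responds to a change from a six-membered to a five-membered aromatic ring, not only to a swap between pyridyl groups. This step is as large as a 5.5-fold lower number from compound 1 to compound 2 (0.74 log units; beyond the scatter), and it leaves compound 4 lowest of the four. Nothing available explains why the furan-3-yl compound gives the lower number. From the compounds shown here alone, whether a thiophene or a plain phenyl ring at this place would lower the number further remains open. So does whether furan-3-yl gives a similar step with methoxy in place of methylsulfanyl.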